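Third methoxy on the carbonyl-side ring of compound 3

The source may hold more compounds than are shown below. What is called first, only, known or untested is meant among the compounds shown, and "the series" means these compounds.

Among the measured compounds shown here, compound 3 `COc1ccc(C(=O)/C=C/c2cc(-c3cc(OC)c(OC)c(OC)c3)n[nH]2)cc1OC` gives the lowest of the three numbers so far in a functional assay on PC-3 cells (Homo sapiens) for inhibition, read by sulforhodamine B assay, with a stated time of 48 h (a higher number here means a weaker inhibitor of growth, a lower number a stronger inhibitor of growth), at 2800 nM. Compound 1 `COc1cc(-c2cc(/C=C/C(=O)c3ccc(N)cc3)[nH]n2)cc(OC)c1OC` gives 10400 nM and compound 2 `COc1ccc(-c2cc(/C=C/C(=O)c3cc(OC)c(OC)c(OC)c3)[nH]n2)cc1OC` gives 10300 nM; those two values lie within the scatter of each other. For the measured compounds named here, the one step recorded is a 3.7-fold lower number from compound 1 to compound 3 (0.57 log units; beyond the scatter). Compound 4 `COc1cc(C(=O)/C=C/c2cc(-c3cc(OC)c(OC)c(OC)c3)n[nH]2)cc(OC)c1OC` differs from compound 3 by methoxy in place of hydrogen on an aromatic carbon. Going by the values given here, no measured step exchanges hydrogen for methoxy on that ring, so the step from compound 1 to compound 3 bears on it only in that an aryl group on the carbonyl carbon has shifted the number by a modest amount. Compound 2 carries a trimethoxyphenyl on its carbonyl carbon and compound 3 a dimethoxyphenyl, but they differ elsewhere too, and their two values show only that each arrangement is reached. Compound 4 is therefore expected to stay within the scatter of compound 3, as a step of a 1.4-fold higher number from compound 3 to compound 4 (0.15 log units; within the scatter). The estimate for compound 4 in this assay is 4000 nM, in a range from 1500 nM to 12000 nM.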

Compound 4, concentration for total growth inhibition: 3290 nM
Compound 4: the middle estimate sits 1.2-fold (0.08 log units) above what was measured; low and high end bracket the measured number.
By their numbers in this assay, from the lowest: compounds 3 and 4 (each within the scatter of the next); then compounds 2 and 1 (each within the scatter of the next).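

In this assay, the carbonyl-side ring takes methoxy in place of hydrogen with a 1.2-fold higher number from compound 3 to compound 4 (0.07 log units; within the scatter) as the whole change, so this position shows no measurable response to the added group. The same exchange on the other aromatic ring gives a 3.1-fold lower number from compound 2 to compound 4 (0.50 log units; beyond the scatter) and lies beyond the scatter, so the effect of this exchange depends on the ring that carries it, at least across these two pairs. No measured evidence accounts for the difference between the two rings.

As far as these compounds go, whether the carbonyl-side position would respond to a hydroxyl, a chlorine or a longer ethoxy group remains open. The compounds shown also leave open whether the contrast between the two rings extends beyond these two pairs or beyond PC-3 cells.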